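The source may hold more compounds than are shown below. What is called first, only, known or untested is meant among the compounds shown, and "the series" means these compounds.

Of the compounds shown here, two have been measured in a physicochemical assay for solubility, read by LC-MS, in phosphate buffer, measured as kinetic solubility, with a stated time of 4 h, at pH 7.4; on this read-out lower numbers stand for lower solubility and higher numbers for higher solubility. Compound 1, `Cc1ccc(Nc2nc(-c3cc(C(F)(F)F)ccc3F)co2)cc1`, gives 5900 nM in this assay. Compound 2, `CCOC(=O)c1cc(-c2coc(Nc3ccc(C)cc3)n2)on1`, gives 6800 nM in this assay, the higher of the two numbers, although the gap to compound 1 lies within the scatter of the measurement, so the two cannot be ranked against each other.

Compound 3, `Cc1ccc(Nc2nc(-c3cc(C(=O)Nc4ccccn4)no3)co2)cc1`, differs from compound 2 in one place: (pyridin-2-yl)amino in place of ethoxy on a carbonyl carbon, so that the ethoxycarbonyl group of compound 2 reads as a (pyridin-2-yl)carbamoyl group in compound 3. Going by the values given here, no pair of measured compounds shows this kind of change, so its effect in this assay can only be guessed. Compound 3 is expected to give a somewhat lower number than compound 2, with the step of a 2.3-fold lower number from compound 2 to compound 3 (0.36 log units; beyond the scatter) estimated as modest, near the edge of the scatter rather than far beyond it. For compound 3 the solubility in this assay is therefore estimated at 3000 nM, with a range from 1000 nM to 10000 nM.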

Compound 3, solubility: 9300 nM
Estimate against measurement, compound 3: 3.1-fold (0.49 log units) below; low and high end bracket the measured number.
By their numbers in this assay, from the lowest: compounds 1, 2 and 3 (each within the scatter of the next).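

In this assay, exchanging ethoxy for (pyridin-2-yl)amino on a carbonyl carbon gives a 1.4-fold higher number from compound 2 to compound 3 (0.14 log units; within the scatter), so this first step at the position cannot be told apart from repeat measurement. The ester is therefore not required for compound 3 to read alongside compound 2, even though the entering group brings a six-membered aromatic ring and a hydrogen-bond donor that ethoxy lacks. Nothing available explains why these two compounds cannot be separated in this measurement.

This single step cannot show which part of the new group matters, and it leaves open how the number would respond to phenylamino, which lacks the ring nitrogen, or to methyl on the amide nitrogen, which removes the amide hydrogen. It also leaves open whether a carboxylic acid or a simple amine-bearing chain on the same carbonyl carbon would yield a step beyond the scatter, or whether this position stays as flat as it appears from one pair.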